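A few compounds are considered here, and "the series" means these few. Any claim that something is new, unique, unknown or untested is made for them only; others in the source may bear on it.

Measured so far:
Compound 1 `CCC(C)NC(=C\C(=O)/C=C/c1ccc(O)c(OC)c1)/C=C/c1ccc(O)c(OC)c1`: > 25000 nM
Compound 2 `COc1cc(/C=C/C(=O)CC(=O)/C=C/c2ccc(OC(C)=O)c(OC)c2)ccc1OC(C)=O`: > 25000 nM

In an ADME assay on Caco-2 cells (Homo sapiens) for inhibition, read by sulforhodamine B assay, with a stated time of 72 h (a higher number here means a weaker inhibitor, a lower number a stronger inhibitor), compound 1 gives > 25000 nM, which is a limit of the assay and not a number. Compound 2 gives > 25000 nM, which is likewise a limit. What is known therefore comes down to the limit of > 25000 nM in this assay, at which 2 of the 2 values shown sit. Among the compounds with values here, no step between measured compounds is available.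

The next compound to be tested is compound 3 `COc1cc(/C=C/C(=O)/C=C(/C=C/c2ccc(O)c(OC)c2)NCC(C)C)ccc1O`, which has not yet been measured. It differs from compound 1 by isobutyl in place of sec-butyl on an amine nitrogen; the two have the same atoms, joined differently, with isobutyl in place of sec-butyl on an amine nitrogen.

No step beyond the scatter is expected in this assay, and neither direction is favoured. That expectation starts from compound 1, whose limit of > 25000 nM is the only reference point for this change. The estimated change is a step that the limit leaves unreadable from compound 1 to compound 3. The assay may well report only a limit again. For compound 3 the expected value is 30000 nM, with an estimated range from 12000 nM to 60000 nM.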

Compound 3, half-maximal inhibitory concentration: > 25000 nM
Compound 3: only a limit was reported (the forecaster's own chance of this, stated with the estimate: 70%); the middle value does not contradict the limit.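

In this assay compound 3 gives > 25000 nM, which is a limit of the assay and not a number. Compound 1 gives > 25000 nM, likewise a limit, so no step can be read between compound 1 and compound 3. The compounds shown leave open how far isobutyl and sec-butyl differ on the amine nitrogen, and which structures would give a measurable value: the limit of > 25000 nM in this assay, at which 3 of the 3 values shown sit.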